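Swapping the halogen on the aryl ring of compound 2

A few compounds are considered here, and "the series" means these few. Any claim that something is new, unique, unknown or untested is made for them only; others in the source may bear on it.

Two hydrazone amides built on one shared core have been measured in a functional assay on MDA-MB-231 cells (Homo sapiens) for inhibition, read by sulforhodamine B assay, with a stated time of 48 h; a lower number here means a stronger inhibitor of growth, a higher number a weaker inhibitor of growth. Compound 1 `COc1cccc(/C=N\NC(=O)C2=C(Cl)c3ccccc3CCC2)c1` carries a 3-methoxyphenyl on the carbon that is double-bonded to nitrogen and gives 300 nM. Compound 2 `O=C(N/N=C\c1ccc(Cl)cc1)C1=C(Cl)c2ccccc2CCC1` carries a 4-chlorophenyl at that carbon instead and gives 260 nM. Among the measured compounds shown here, the one step between them, a 1.2-fold lower number from compound 1 to compound 2 (0.06 log units; within the scatter), shows that exchanging the aryl group left the number essentially unchanged. Compound 2 thus stands at one end of the two numbers, with compound 1 alongside it within the scatter. Compound 3 `O=C(N/N=C\c1ccc(F)cc1)C1=C(Cl)c2ccccc2CCC1` differs from compound 2 by fluoro in place of chloro on an aromatic carbon. For the measured compounds named here, the only step that bears on this, a 1.2-fold lower number from compound 1 to compound 2 (0.06 log units; within the scatter), was itself within the scatter, so no step beyond the scatter is expected here either. Compound 3 is therefore estimated at 300 nM, with a range from 150 nM to 650 nM, an expected step of a 1.2-fold higher number from compound 2 to compound 3 (0.06 log units; within the scatter).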

Compound 3, concentration for 50% growth inhibition: 410 nM
Compound 3: middle estimate off by 1.4-fold (0.14 log units), on the low side; the range from low to high includes it.
By their numbers in this assay, from the lowest: compounds 2, 1 and 3 (each within the scatter of the next).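

Fluoro in place of chloro changes a single atom on the aryl ring, whereas the earlier step exchanged the whole aryl group, and in this assay this smaller change also stays within the scatter (a 1.6-fold higher number from compound 2 to compound 3 (0.20 log units; within the scatter)). The step between the two other aryl groups gives the same reading (a 1.4-fold higher number from compound 1 to compound 3 (0.14 log units; within the scatter)), so all three aryl groups shown, 3-methoxyphenyl, 4-chlorophenyl and 4-fluorophenyl, lie within the scatter of one another. Nothing further is available that bears on these numbers.

Going by these compounds, only two halogens have been compared at this place, para to a large group, so it remains open whether an amine or a carboxylic acid there would give a step beyond the scatter. The compounds shown also leave open how a longer chain on the ring would read.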